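Swapping furan-2-yl for 4-(trifluoromethyl)phenyl on a carbonyl carbon

A few compounds are considered here, and "the series" means these few. Any claim that something is new, unique, unknown or untested is made for them only; others in the source may bear on it.

Measured in an ADME assay on cells (Hepatocyte, Mus musculus) for metabolic stability, with a stated time of 30 min; on this read-out lower numbers stand for a less stable compound and higher numbers for a more stable compound:
- compound 1 `Cc1ccc(C(=O)OC2CCC(CN3CCN(c4cc(=O)c5cc(C(F)(F)F)cc([N+](=O)[O-])c5s4)CC3)CC2)cc1`: 18%
- compound 2 `CC(=O)OC1CCC(CN2CCN(c3cc(=O)c4cc(C(F)(F)F)cc([N+](=O)[O-])c4s3)CC2)CC1`: 0%
- compound 3 `O=C(OC1CCC(CN2CCN(c3cc(=O)c4cc(C(F)(F)F)cc([N+](=O)[O-])c4s3)CC2)CC1)c1ccco1`: 0.6%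

Little of compound 3 survives in this assay, where it gives 0.6%. It cannot be told apart from compound 2, since the measurements show a number 0.6 percentage points higher from compound 2 to compound 3 (within the scatter). Compound 1 clearly stands apart, with a number 17.4 percentage points lower from compound 1 to compound 3 (beyond the scatter).

The next compound, compound 4 `O=C(OC1CCC(CN2CCN(c3cc(=O)c4cc(C(F)(F)F)cc([N+](=O)[O-])c4s3)CC2)CC1)c1ccc(C(F)(F)F)cc1`, keeps everything but one group: 4-(trifluoromethyl)phenyl in place of furan-2-yl on a carbonyl carbon. The count of that change reads: 4-(trifluoromethyl)phenyl in place of furan-2-yl on a carbonyl carbon.

Among the measured compounds shown here, two measured steps bear on this. One is the step just given for furan-2-yl, and the other is a number 18 percentage points lower from compound 1 to compound 2 (beyond the scatter). For the measured compounds named here, both are modest but beyond the scatter, and both lead away from compound 1, the only measured compound with a six-membered aromatic ring of carbon only on that carbonyl carbon. Compound 4 has such a ring too, so it is expected to lie nearer compound 1 at 18% than compound 3. Going by the values given here, no measured compound carries 4-(trifluoromethyl)phenyl itself, so this expectation is loose.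

The expected change is a number 13.4 percentage points higher from compound 3 to compound 4 (beyond the scatter).

Compound 4 is estimated at 14%, within an expected range from 2% to 32%.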

Compound 4, percent of the compound remaining: 28.8%
Compound 4: middle estimate off by 14.8 percentage points, on the low side; the range from low to high includes it.
By their numbers in this assay, from the lowest: compounds 2 and 3 (each within the scatter of the next); then compound 1; then compound 4.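

In this assay, the group on this carbonyl carbon matters even when the six-membered aromatic ring of carbon only stays in place: the result is a number 10.8 percentage points higher from compound 1 to compound 4 (beyond the scatter), with trifluoromethyl in place of methyl on an aromatic carbon. The gap to the two compounds without such a ring also widens, with a number 28.2 percentage points higher from compound 3 to compound 4 (beyond the scatter) and a number 28.8 percentage points higher from compound 2 to compound 4 (beyond the scatter), so among these four compounds, the two with that ring on the carbonyl carbon, compound 1 and compound 4, both stand clear of compound 2 and compound 3, and no compound shown goes against this. Nothing measured here says why these steps take the size they do.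

The compounds shown leave open what a plain phenyl with nothing on the ring would give, and whether a chlorine atom or a methoxy group on the ring would land nearer compound 1 or compound 4. They also leave open whether the same groups would behave alike if an amide nitrogen took the place of the oxygen on this carbonyl group.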